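Reversing one stereocentre in compound 3

This account rests on a few compounds, and the source may have more. Where it says the series, first, only, none or still open, it means among the compounds named here.

In a functional assay on BXPC-3 cells (Homo sapiens) for inhibition, read by MTT assay, with a stated time of 7 days (on this read-out lower numbers stand for stronger inhibition and higher numbers for weaker inhibition), compound 1 `CCN(CC)S(=O)(=O)c1ccc(S(=O)(=O)N2CCC[C@@H](C(=O)N3CCC(OC)CC3)C2)cc1` gives 1420 nM, compound 2 `CCN(CC)S(=O)(=O)c1ccc(S(=O)(=O)N2CCC[C@@H](C(=O)N3CCC(F)(F)CC3)C2)cc1` gives 120 nM and compound 3 `CCN(CC)S(=O)(=O)c1ccc(S(=O)(=O)N2CCC[C@@H](C(=O)N3CC[C@@H](OC)C3)C2)cc1` gives 11500 nM. Compound 3 therefore has the highest number of the three and is the weakest so far.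

Compound 4 `CCN(CC)S(=O)(=O)c1ccc(S(=O)(=O)N2CCC[C@@H](C(=O)N3CC[C@H](OC)C3)C2)cc1` departs from compound 3 in one respect: the two compounds have the same atoms and bonds and differ only in configuration as drawn: 1 of 2 stereo elements differ; a stereocentre at a saturated ring carbon is drawn R in compound 3 and S in compound 4. Among the measured compounds shown here, no measured pair isolates a change of configuration, so the evidence is indirect. The measured steps all replace the amine portion on the carbonyl carbon: a 12-fold lower number from compound 1 to compound 2 (1.07 log units; beyond the scatter), an 8.1-fold higher number from compound 1 to compound 3 (0.91 log units; beyond the scatter) and a 96-fold higher number from compound 2 to compound 3 (1.98 log units; beyond the scatter). They show that the number can move far with changes at this end of the molecule in these three compounds, but they do not show what a single stereocentre does. A step smaller than the largest of these is expected in this assay. The direction is open, with a slight lean towards a lower number. The estimated change is a 1.9-fold lower number from compound 3 to compound 4 (0.28 log units; within the scatter). For compound 4 the expected value is 6000 nM, with an estimated range of 1500 nM to 20000 nM.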

Compound 4, half-maximal inhibitory concentration: 6750 nM
Compound 4: middle estimate off by 1.1-fold (0.05 log units), on the low side; the measured number falls inside the stated range.
By their numbers in this assay, from the lowest: compound 2; then compound 1; then compounds 4 and 3 (each within the scatter of the next).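

In this assay, among the compounds shown here, the only isolated change of configuration, at a saturated ring carbon, gives a 1.7-fold lower number from compound 3 to compound 4 (0.23 log units; within the scatter), so the R and S drawings cannot be told apart in this pair. Either configuration leaves the 3-methoxypyrrolidin-1-yl amides well separated from the 4,4-difluoropiperidin-1-yl amide, with a 56-fold higher number from compound 2 to compound 4 (1.75 log units; beyond the scatter), and from the 4-methoxypiperidin-1-yl amide, with a 4.8-fold higher number from compound 1 to compound 4 (0.68 log units; beyond the scatter), both beyond the scatter. The pair tests this stereocentre alone, with no other structural change involved: the fact that compounds 3 and 4 differ only in the configuration as drawn.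

As far as these compounds go, whether configuration at this carbon matters as little with a hydroxy group or an amine in place of methoxy remains open. Also open, from the compounds shown here alone, is the role of the second stereo element, drawn alike in compound 3 and compound 4.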